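This account rests on a few compounds, and the source may have more. Where it says the series, first, only, none or still open, it means among the compounds named here.

Compound 1 `Nc1[nH]nc2nnc(-c3ccco3)cc12` was tested in a functional assay on HT-29 cells (Homo sapiens) for cytotoxicity; on this read-out lower numbers stand for stronger inhibition and higher numbers for weaker inhibition. In this assay compound 1 gives > 100000 nM, which is a limit of the assay and not a number. Compound 2 `Nc1nn(COCCO)c2nnc(-c3ccccc3)c(-c3ccccc3)c12` also sits at a limit in this assay, with > 100000 nM. Compound 3 `COc1ccc(-c2[nH]nc3nnc(N)c-3c2-c2ccc(OC)cc2)cc1` likewise gives only a limit, > 100000 nM. Compound 1 therefore stands at the limit of > 100000 nM in this assay, at which 3 of the 3 values shown sit, level with every other value shown. Compound 4 `Nc1[nH]nc2nnc(-c3ccco3)c(-c3ccco3)c12` has not yet been measured; it differs from compound 1 by furan-2-yl in place of hydrogen on an aromatic carbon. Compound 3 already carries two aromatic rings on the shared core and still reaches only the limit > 100000 nM, so no step beyond the scatter is expected in this assay. Compound 4 is expected to give about 100000 nM, between 50000 nM and 300000 nM. The expected step of a number no higher from compound 1 to compound 4 (the limit leaves the size open) is essentially none.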

Compound 4, half-maximal inhibitory concentration: > 100000 nM
Compound 4: only a limit was reported (the forecaster's own chance of this, stated with the estimate: 90%); the middle value sits exactly at the limit.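

Going by these compounds alone, compound 1 and compound 4 both give only a limit, so no step between them can be read: the limit of > 100000 nM in this assay, at which 4 of the 4 values shown sit. What furan-2-yl in place of hydrogen does in this assay, and whether any compound shown would give an actual number there, stays open.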